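Benzyl substitution and orexin receptor type 1 binding

The compounds below may be only part of what the source reports. "The series", "measured", "known", "first", "only" and "open" are said of these compounds alone.

Measured compounds:
compound 1, `COc1cc(F)c(CN2C(=O)N(c3cnc(OC)c(OC)c3)S(=O)(=O)c3ccccc32)c(F)c1`, 2.51 nM
compound 2, `COc1cc(F)c(CN2C(=O)N(c3ccc(OC)c(OC)c3)S(=O)(=O)c3ccccc32)c(Cl)c1`, 0.398 nM

The two measured compounds were tested in an assay on isolated protein for displacement of a labelled ligand from Orexin/Hypocretin receptor type 1 (Homo sapiens), with a stated time of 90 min; a higher number here means a weaker inhibitor, a lower number a stronger inhibitor. Compound 1 gives 2.51 nM, and compound 2 gives 0.398 nM. Compound 2 thus stands at the lowest of the two numbers, with compound 1 giving the nearest value, a number that lies beyond the scatter above that of compound 2. Among the measured compounds shown here, the two compounds differ in more than one place, so the pair shows only that the values are distinct, not which change carries the gap.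

Compound 3, `COc1ccc(N2C(=O)N(Cc3ccc(F)cc3Cl)c3ccccc3S2(=O)=O)cc1OC`, has not yet been measured in this assay. It differs from compound 2 in one place: 2-chloro-4-fluorophenyl in place of 2-chloro-6-fluoro-4-methoxyphenyl on a saturated chain carbon bound to an amide-type nitrogen in a ring. For the measured compounds named here, no measured pair in this set isolates such a change, so the step can only be expected rather than read from precedent. A change of this kind on the saturated chain carbon bound to the amide-type nitrogen is expected to cost some affinity, and the step of a 3.8-fold higher number from compound 2 to compound 3 (0.58 log units; beyond the scatter) is expected to be modest, toward a higher number. Compound 3 is estimated at 1.5 nM, within a range from 0.4 nM to 6 nM.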

Compound 3, inhibition constant: > 2510 nM
Compound 3 ended at the assay's limit (the forecaster's own chance of this, stated with the estimate: 0%); at least 1600-fold (3.22 log units) between middle value and limit.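

In this assay, among the compounds shown here, the change from 2-chloro-6-fluoro-4-methoxybenzyl to 2-chloro-4-fluorobenzyl, on a saturated chain carbon bound to an amide-type nitrogen in a ring, gives an at least 6300-fold higher number from compound 2 to compound 3 (3.79 log units; beyond the scatter), and this is the first step here that isolates a single place. The earlier pair differed in more than one place and could not tie a gap to any one of them, whereas this step ties a large loss of binding to this one substituted phenyl group, with the rest of compound 2 unchanged. The value of compound 3 is a limit and not a number, so the step fixes only a minimum for the change: the limit of > 2510 nM in this assay, at which 1 of the 3 values shown sits.

The compounds shown leave open whether the step follows from the loss of the methoxy group, from the different placing of fluorine, or from both together, since the two go together in this one change. They also leave open how compounds with a hydroxyl, an ethoxy group or an amine in place of that methoxy group would read in this assay, and whether the 2-chloro group matters at this position.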